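A Diethylamino Variant of the Indole Hydrazone Series

This account rests on a few compounds, and the source may have more. Where it says the series, first, only, none or still open, it means among the compounds named here.

Of the compounds shown here, three sharing one core have been measured in a functional assay on NCI-H460 cells (Homo sapiens) for cytotoxicity, read by MTT assay, with a stated time of 72 h; on this read-out higher numbers stand for weaker inhibition and lower numbers for stronger inhibition. Compound 1 `CCN(CC)Cc1ccc2nc(NC(=O)N/N=C/c3c[nH]c4ccccc34)sc2c1` gives 3140 nM. For the measured compounds named here, compound 2 `CCN(CC)Cc1ccc2nc(NC(=O)N/N=C/c3cn(Cc4ccc(C)cc4)c4ccccc34)sc2c1` gives 320 nM, and the only single-point step available, a 9.8-fold lower number from compound 1 to compound 2 (0.99 log units; beyond the scatter), concerns 4-methylbenzyl replacing hydrogen on the aromatic nitrogen. Compound 3 `CN(C)Cc1ccc2nc(NC(=O)N/N=C/c3cn(Cc4ccc(Cl)cc4Cl)c4ccccc34)sc2c1` gives 950 nM, which places it second highest of the three values: the value of compound 2 lies lower and that of compound 1 lies higher, each by a margin beyond the scatter.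

Compound 4 `CCN(CC)Cc1ccc2nc(NC(=O)N/N=C/c3cn(Cc4ccc(Cl)cc4Cl)c4ccccc34)sc2c1` differs from compound 3 in one place only: diethylamino in place of dimethylamino on a saturated chain carbon bound to an aromatic carbon. Going by the values given here, no measured pair probes this particular exchange, since compounds 2 and 3 differ in two places at once and the step from compound 1 to compound 2 alters a different position. Among the compounds with values here, with no directly relevant step, the expected step of no change at the digits printed from compound 3 to compound 4 (within the scatter) is none beyond the scatter. Compound 4 is therefore expected to give 950 nM, with a range from 400 nM to 2300 nM in this assay.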

Compound 4, half-maximal inhibitory concentration: 1080 nM
Compound 4: the middle estimate sits 1.1-fold (0.06 log units) below what was measured; low and high end bracket the measured number.
By their numbers in this assay, from the lowest: compound 2; then compounds 3 and 4 (each within the scatter of the next); then compound 1.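

In this assay, for the compounds shown here, diethylamino in place of dimethylamino on a saturated chain carbon bound to an aromatic carbon gives the first direct reading of this change, and the step lies within the scatter (a 1.1-fold higher number from compound 3 to compound 4 (0.06 log units; within the scatter)). With diethylamino held fixed, a change of the group on the aromatic nitrogen still gives a step beyond the scatter (a 2.9-fold lower number from compound 1 to compound 4 (0.46 log units; beyond the scatter)), while 2,4-dichlorophenyl in place of 4-methylphenyl on a saturated chain carbon bound to an aromatic nitrogen gives a step in the opposite direction (a 3.4-fold higher number from compound 2 to compound 4 (0.53 log units; beyond the scatter)). Among these single-place steps, the number therefore moves beyond the scatter with the aromatic-nitrogen group but not with this amine exchange.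

Nothing available explains these numbers. The compounds shown leave open whether a ring amine such as morpholine or pyrrolidine in place of diethylamino would also stay within the scatter.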